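From a Bromo to a Trifluoromethyl Group: Compound 4

The source may report more compounds than this note shows. Statements on the series, on what has been measured and on what is new or still open speak of the compounds shown alone.

Measured in an assay on isolated protein for displacement of a labelled ligand from D(4) dopamine receptor (Homo sapiens); a lower number here means a stronger inhibitor, a higher number a weaker inhibitor:
Compound 1 `O=C(NC1CCN(Cc2ccccc2Cl)CC1)c1cccc2ccccc12`: 329 nM
Compound 2 `O=C(NC1CCN(Cc2cccc(Cl)c2)CC1)c1cccc2ccccc12`: 116 nM
Compound 3 `O=C(NC1CCN(Cc2ccc(Br)cc2)CC1)c1cccc2ccccc12`: 44 nM

Compound 3 gives the lowest number of the three, below compound 2 by a 2.6-fold lower number from compound 2 to compound 3 (0.42 log units; beyond the scatter) and below compound 1 by a 7.5-fold lower number from compound 1 to compound 3 (0.87 log units; beyond the scatter). Compound 4 `O=C(NC1CCN(Cc2ccc(C(F)(F)F)cc2)CC1)c1cccc2ccccc12` differs from it in one place: trifluoromethyl in place of bromo on an aromatic carbon. Going by the values given here, none of the measured steps exchanges one group for another at a fixed place; all three move a halogen to another position on the ring, as in a 2.8-fold lower number from compound 1 to compound 2 (0.45 log units; beyond the scatter). They therefore bear only loosely on this change, and no shift beyond the scatter is expected in either direction in this assay. Compound 4 is estimated at 50 nM, with a range from 20 nM to 130 nM. This estimate means an expected step of a 1.1-fold higher number from compound 3 to compound 4 (0.06 log units; within the scatter).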

Compound 4, inhibition constant: 96 nM
Estimate against measurement, compound 4: 1.9-fold (0.28 log units) below; the measured number falls inside the stated range.
By their numbers in this assay, from the lowest: compound 3; then compounds 4 and 2 (each within the scatter of the next); then compound 1.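

In this assay, this is the first step shown that exchanges one group for another at a fixed place on the ring, and trifluoromethyl gives a higher number than bromo (a 2.2-fold higher number from compound 3 to compound 4 (0.34 log units; beyond the scatter)). The new group leaves compound 4 level with the 3-chlorophenyl compound (a 1.2-fold lower number from compound 2 to compound 4 (0.08 log units; within the scatter)). Compound 4 still keeps a clear margin over the 2-chlorophenyl compound (a 3.4-fold lower number from compound 1 to compound 4 (0.53 log units; beyond the scatter)).

As far as these compounds go, whether a nitrile, a methoxy group or an amine at this place would match bromo remains open. Nothing shown here explains the step from bromo to trifluoromethyl.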